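The source may report more compounds than this note shows. Statements on the series, on what has been measured and on what is new or still open speak of the compounds shown alone.

Measured so far in a functional assay on the whole organism (strain L.) for inhibition, with Echinochloa crus-galli as the target, with a stated time of 72 h, tested at 10 mg/L; a higher number here means more inhibition of growth at the concentration tested, a lower number less inhibition of growth:
compound 1 `COc1cc(Cl)nc(NC(=S)NC(=O)c2c(-c3ccc(Cl)cc3Cl)noc2C)n1`: 18.5%
compound 2 `COc1cc(SC)nc2n/c(=N/C(=O)c3c(-c4ccc(Cl)cc4Cl)noc3C)sn12`: 21.4%

Compound 1 gives the smaller figure of the two shown, with compound 2 within the scatter of it, so the two cannot be told apart. Compound 3 `CSc1cc(C)nc(NC(=S)NC(=O)c2c(-c3ccc(Cl)cc3Cl)noc2C)n1` is not yet measured. It differs from compound 1 in one place: 4-methyl-6-(methylsulfanyl)pyrimidin-2-yl in place of 4-chloro-6-methoxypyrimidin-2-yl on an amide-type nitrogen. Within the data shown here, no measured pair shows this kind of change, and the two measured compounds sit close together, so no movement beyond the scatter is expected, in either direction. Compound 3 is expected to give about 20% in this assay, within 5% to 38%. The step this expectation means is a number 1.5 percentage points higher from compound 1 to compound 3 (within the scatter).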

Compound 3, percent growth inhibition at one concentration: 27.4%
Compound 3: middle estimate off by 7.4 percentage points, on the low side; the measured number falls inside the stated range.
By their numbers in this assay, from the lowest: compounds 1, 2 and 3 (each within the scatter of the next).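

In this assay, among these compounds, the first single-place comparison gives a number 8.9 percentage points higher from compound 1 to compound 3 (within the scatter) for 4-methyl-6-(methylsulfanyl)pyrimidin-2-yl in place of 4-chloro-6-methoxypyrimidin-2-yl on the amide-type nitrogen. This exchange, with the thiocarbonyl carbon kept as the other neighbour, therefore cannot be told apart from no change. Nothing available bears on a cause for this step.

Still open, as far as these compounds go, is whether a dimethylamino group or a longer chain such as butylsulfanyl on this pyrimidine would move the number beyond the scatter. The separate effects of the methyl and methylsulfanyl groups also remain unresolved.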